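The source may report more compounds than this note shows. Statements on the series, on what has been measured and on what is new or still open speak of the compounds shown alone.

Three compounds share one core and differ only in the group on a carbonyl carbon whose other neighbour is an amide-type nitrogen. Compound 1 `CC(C)CCC(=O)N[C@@H](C(=O)N1CCC(c2ccc(Cl)cc2)CC1)C(C)C` carries an isopentyl group there, and in an assay on THP-1 cells for displacement of a labelled ligand from C-C chemokine receptor type 1 (Homo sapiens) (a lower number here means a stronger inhibitor, a higher number a weaker inhibitor), compound 1 gives 26 nM. Compound 2 `CC(C)[C@@H](NC(=O)c1nc2ccccc2s1)C(=O)N1CCC(c2ccc(Cl)cc2)CC1` carries a 1,3-benzothiazol-2-yl group, and in this assay compound 2 gives 18 nM. Compound 3 `CC(C)[C@@H](NC(=O)c1cccc(F)c1)C(=O)N1CCC(c2ccc(Cl)cc2)CC1` carries a 3-fluorophenyl group, and in this assay compound 3 gives 24 nM. Its number is the second highest of the three, though all three lie within the scatter of one another, so none can be called stronger. Compound 4 `Cc1ccccc1C(=O)N[C@@H](C(=O)N1CCC(c2ccc(Cl)cc2)CC1)C(C)C` is the next step: 2-methylphenyl in place of 3-fluorophenyl on a carbonyl carbon. The steps already seen at this position bear on it: a 1.1-fold lower number from compound 1 to compound 3 (0.03 log units; within the scatter), a 1.3-fold higher number from compound 2 to compound 3 (0.12 log units; within the scatter) and a 1.4-fold lower number from compound 1 to compound 2 (0.16 log units; within the scatter), each within the scatter, although none of them exchanged one aromatic ring of carbon only for another. Exchanging the group on this carbonyl has so far moved nothing beyond the scatter, so no step beyond the scatter is expected for compound 4 either, a 1.0-fold higher number from compound 3 to compound 4 (0.02 log units; within the scatter). For compound 4 the estimate in this assay is 25 nM, with a range from 10 nM to 60 nM.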

Compound 4, half-maximal inhibitory concentration: 32 nM
Beside the measured number, compound 4's estimate is 1.3-fold (0.11 log units) below it; the range from low to high includes it.
By their numbers in this assay, from the lowest: compounds 2, 3, 1 and 4 (each within the scatter of the next).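

Going by these compounds alone, this is the first exchange of one aromatic ring of carbon only for another on this carbonyl, and in this assay it gives a 1.3-fold higher number from compound 3 to compound 4 (0.12 log units; within the scatter) and so stays within the scatter. The steps from the other two groups, a 1.8-fold higher number from compound 2 to compound 4 (0.25 log units; within the scatter) and a 1.2-fold higher number from compound 1 to compound 4 (0.09 log units; within the scatter) as well, also stay within it, even though the first of these is the largest step yet at this position, so isopentyl, 1,3-benzothiazol-2-yl, 3-fluorophenyl and 2-methylphenyl cannot be told apart here. No measurement available accounts for this.

The compounds shown leave open whether an amine or a carboxylic acid on this carbonyl would also stay within the scatter. They also leave open what 2-fluorophenyl or 3-methylphenyl would give, which would separate the choice of fluorine or methyl from its place on the ring.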